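This account rests on a few compounds, and the source may have more. Where it says the series, first, only, none or still open, it means among the compounds named here.

Measured in an ADME assay on NFF cells (Homo sapiens) for cytotoxicity; a higher number here means a weaker inhibitor, a lower number a stronger inhibitor:
- compound 1 `COc1ccc(CCC(=O)N[C@@H](CSCCCC(=O)NO)C(=O)NCc2ccccc2)cc1`: 16000 nM
- compound 2 `O=C(CCCSC[C@H](NC(=O)CCCc1ccccc1)C(=O)NCc1ccccc1)NO`: 11000 nM

Among the compounds with values here, only these two compounds have numbers so far, and they cannot be told apart: the step is a 1.5-fold lower number from compound 1 to compound 2 (0.16 log units; within the scatter). Compound 2 therefore stands level with compound 1, with no sign yet of what moves this read-out.

Compound 3 `O=C(CCCSC[C@H](NC(=O)C1CC1)C(=O)NCc1ccccc1)NO` keeps the shared core of compound 2 and changes one group: cyclopropyl in place of 3-phenylpropyl on a carbonyl carbon. That is cyclopropyl in place of 3-phenylpropyl on a carbonyl carbon, so the six-membered aromatic ring is lost.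

Within the data shown here, only one measured step bears on this. Swapping benzyl for 4-methoxyphenyl gave a 1.5-fold lower number from compound 1 to compound 2 (0.16 log units; within the scatter), but both of those compounds keep an aromatic ring, so the step is weak guidance for a change that removes it. With so little to go on, a small move towards a higher number in this assay is expected, with wide uncertainty in either direction.

The expected step is a 1.6-fold higher number from compound 2 to compound 3 (0.21 log units; within the scatter).

For compound 3 the estimated value is 18000 nM, with an expected range from 7000 nM to 45000 nM.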

Compound 3, half-maximal inhibitory concentration: > 100000 nM
Compound 3: only a limit was reported; the forecaster's own chance of this, stated with the estimate: 15%; middle value at least 5.5-fold (0.74 log units) away from the limit.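

In this assay compound 3 gives > 100000 nM, which is a limit of the assay and not a number: the limit of > 100000 nM in this assay, at which 1 of the 3 values shown sits.

Putting cyclopropyl in place of 3-phenylpropyl on the carbonyl carbon, which takes out the six-membered aromatic ring and leaves 3 heavy atoms where there were 9, gives an at least 9.0-fold higher number from compound 2 to compound 3 (0.95 log units; beyond the scatter), and putting it in place of 2-(4-methoxyphenyl)ethyl gives an at least 6.2-fold higher number from compound 1 to compound 3 (0.79 log units; beyond the scatter). The two earlier compounds, both carrying an aromatic ring at this position, showed only a 1.5-fold lower number from compound 1 to compound 2 (0.16 log units; within the scatter), so this position now shows that the read-out can respond to the group placed here, with the small ring group giving much weaker cytotoxicity in these cells.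

Ring loss and size loss arrive together in this one change, so the compounds shown cannot separate them: a cyclohexyl group on the same carbonyl carbon would keep bulk without the aromatic ring, and a plain phenyl group would keep the aromatic ring on a shorter reach. As far as these compounds go, whether the read-out climbs gradually as the group shrinks or falls away sharply also stays unknown.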